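Series notes: chloro for hydrogen, second occurrence

A few compounds are considered here, and "the series" means these few. Any claim that something is new, unique, unknown or untested is made for them only; others in the source may bear on it.

Compound 1 `ClCc1ccccc1Cn1cnc2c(Cl)nc(Cl)nc21` and compound 2 `ClCc1ccccc1Cn1cnc2c(Cl)ncnc21` share a core and differ only by chloro in place of hydrogen on an aromatic carbon. In a functional assay on UACC-257 cells (Homo sapiens) for cytotoxicity, read by sulforhodamine B assay, with a stated time of 48 h (on this read-out higher numbers stand for weaker inhibition of growth and lower numbers for stronger inhibition of growth), compound 1 gives 3890 nM, whereas compound 2 gives 26300 nM; the step is a 6.8-fold lower number from compound 2 to compound 1 (0.83 log units; beyond the scatter). Compound 3 `ClCc1cccc(Cn2cnc3c(Cl)ncnc32)c1` has the same atoms as compound 2 joined differently; the difference between the two cores is not broken down here. In this assay compound 3 gives 37200 nM, which sits within the scatter of compound 2 and beyond that of compound 1. Compound 4 `ClCc1cccc(Cn2cnc3c(Cl)nc(Cl)nc32)c1` differs from compound 3 by chloro in place of hydrogen on an aromatic carbon, the same change, at a place described in the same words, occurring twice among the compounds shown. The step of a 6.8-fold lower number from compound 3 to compound 4 (0.83 log units; beyond the scatter) is expected to resemble the earlier step of a 6.8-fold lower number from compound 2 to compound 1 (0.83 log units; beyond the scatter) because compound 3, at 37200 nM, stands within the scatter of compound 2. Compound 4 is therefore estimated at 5500 nM, expected between 2500 nM and 12000 nM.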

Compound 4, concentration for total growth inhibition: 3460 nM
For compound 4 the middle estimate is 1.6-fold (0.20 log units) above the measured one; low and high end bracket the measured number.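

In this assay, chloro in place of hydrogen on an aromatic carbon gives an 11-fold lower number from compound 3 to compound 4 (1.03 log units; beyond the scatter), and this step agrees with the one on the other core: the same change on two cores in this assay, a 6.8-fold lower number (0.83 log units; beyond the scatter) from compound 2 to compound 1 and an 11-fold lower number (1.03 log units; beyond the scatter) from compound 3 to compound 4, 1.6-fold (0.20 log units) apart, within the scatter of two such steps. In this series, the change therefore carries from the core of compound 2 to the core of compound 3 in the same direction and with a step of like size. Going by these compounds alone, this rests on only two pairs of compounds in one cell line, and it does not show that the step would hold on any further core or in other cells.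

On these data alone, it remains open whether an amine or a methoxy group at the same place, between two ring nitrogen atoms, would give a step of this kind. The compounds shown also leave open how a bromo or fluoro group there would compare with chloro.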